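From Pentan-3-yl to Sec-Butyl: A Clearance Estimate

The source may hold more compounds than are shown below. What is called first, only, known or untested is meant among the compounds shown, and "the series" means these compounds.

In an in vitro ADME assay on microsomes from liver (Canis lupus familiaris) for metabolic stability (a higher number here means faster removal of the compound, a lower number slower removal), compound 2 `CCC(CC)[C@@H]1C(=O)N[C@H](C2Cc3ccccc3C2)C(=O)N1[C@@H](C(=O)N1CCOCC1)c1ccc(C)nc1` gives 5 mL.min-1.g-1. This shares the upper end of the three numbers with compound 1 `CC[C@H](C)[C@@H]1C(=O)N[C@H](C2Cc3ccccc3C2)C(=O)N1[C@@H](C(=O)N1CCOCC1)c1cnc(C)cc1C`, which gives 4 mL.min-1.g-1, within the scatter, while compound 3 `CCC(CC)[C@@H]1C(=O)N[C@H](C2Cc3ccccc3C2)C(=O)N1[C@@H](C(=O)N1CCOCC1)c1ccc(C)nc1C` gives a clearly lower 1 mL.min-1.g-1. Compound 4 `CC[C@H](C)[C@@H]1C(=O)N[C@H](C2Cc3ccccc3C2)C(=O)N1[C@@H](C(=O)N1CCOCC1)c1ccc(C)nc1` is still unmeasured. It has sec-butyl in place of pentan-3-yl on a saturated ring carbon. For the measured compounds named here, the only measured step, a 5.0-fold lower number from compound 2 to compound 3 (0.70 log units; beyond the scatter), comes from a different change, a methyl in place of hydrogen on an aromatic carbon, so it offers little guidance. Compound 1 also carries sec-butyl, and its 4 mL.min-1.g-1 lies within the scatter of compound 2. No change beyond the scatter is therefore expected in this assay, with an estimated 1.3-fold lower number from compound 2 to compound 4 (0.10 log units; within the scatter). Compound 4 is expected at 4 mL.min-1.g-1, within a range of 2 mL.min-1.g-1 to 9 mL.min-1.g-1.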

Compound 4, intrinsic clearance in microsomes: 2 mL.min-1.g-1
Estimate against measurement, compound 4: 2.0-fold (0.30 log units) above; the measured number falls inside the stated range.
By their numbers in this assay, from the lowest: compounds 3, 4, 1 and 2 (each within the scatter of the next, the first and the last beyond it).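

Sec-butyl in place of pentan-3-yl on the saturated ring carbon gives, in this assay, a 2.5-fold lower number from compound 2 to compound 4 (0.40 log units; beyond the scatter), so this chain alone shifts the number. Hydrogen in place of methyl on an aromatic carbon gives a 2.0-fold lower number from compound 1 to compound 4 (0.30 log units; within the scatter), a step inside the scatter. Methyl in place of hydrogen on an aromatic carbon therefore does not behave alike on the two cores: the same change on two cores in this assay, a 5.0-fold lower number (0.70 log units; beyond the scatter) from compound 2 to compound 3 and a 2.0-fold higher number (0.30 log units; within the scatter) from compound 4 to compound 1, 10-fold (1.00 log units) apart, beyond the scatter of two such steps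

Going by these compounds, whether a shorter chain such as ethyl, or a ring such as cyclopentyl, would lower the number further at this carbon stays open. So does the effect of sec-butyl on the core of compound 3.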